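This account rests on a few compounds, and the source may have more. Where it says the series, first, only, none or still open, it means among the compounds named here.

Going by the values given here, compound 1 `Cc1nc(NCc2cccc(C(=O)O)c2)c2cn[nH]c2n1` stands lowest of the two compounds measured so far: in an assay for inhibition of Indoleamine 2,3-dioxygenase 1 (Homo sapiens), read by spectrophotometry, with a stated time of 180 min, tested at 1 uM (a higher number here means a stronger effect of the compound at the concentration tested, a lower number a weaker effect), compound 1 gives 3%, while compound 2 `O=C(O)c1ccc(CNc2cc(Br)cc3[nH]ncc23)cc1` gives 19%, a gap beyond the usual scatter. Compound 3 `O=C(O)c1cccc(CNc2ncnc3[nH]ncc23)c1` differs from compound 1 in one place: hydrogen in place of methyl on an aromatic carbon. Among the compounds with values here, no pair of measured compounds shows this same change, so its effect is not yet known from the data. Removing the methyl is expected to move this assay little, and the step of a number 2 percentage points higher from compound 1 to compound 3 (within the scatter) is estimated to stay within the scatter. Compound 3 is therefore expected to give 5%, with a range from -8% to 20%.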

Compound 3, a percentage reported as inhibition, at one concentration (the size of the read-out at that concentration, not a potency): 2%
Compound 3: the middle estimate sits 3 percentage points above what was measured; low and high end bracket the measured number.
By their numbers in this assay, from the lowest: compounds 3 and 1 (each within the scatter of the next); then compound 2.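

At this aromatic carbon between two ring nitrogen atoms, hydrogen in place of methyl gives a number 1 percentage points lower from compound 1 to compound 3 (within the scatter) in this assay and so the methyl can go without a measurable change. Both numbers lie close to the bottom of the scale, where a further loss would be hard to see. Nothing measured here offers an explanation for this result.

Still open, as far as these compounds go, is whether a different group on this carbon, such as an amine or a methoxy group, would lift the number clear of the scatter.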